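Switching the double-bond geometry of an oxa-chain analogue

The source may hold more compounds than are shown below. What is called first, only, known or untested is meant among the compounds shown, and "the series" means these compounds.

Measured so far:
compound 1, `O=C(O)CC/C=C1/C[C@H]2C[C@@H](O)[C@H](/C=N/NC(=O)Nc3ccc([N+](=O)[O-])cc3)[C@H]2C1`, 20 nM in a functional assay on a cell-free system (plasma) for agonist activity at thromboxane A2 receptor (Homo sapiens); a lower number here means a stronger inhibitor, a higher number a weaker inhibitor
compound 2, `O=C(O)COC/C=C1\C[C@H]2C[C@@H](O)[C@H](/C=N/NC(=O)Nc3ccc([N+](=O)[O-])cc3)[C@H]2C1`, 190 nM in this assay

Compound 2 has the higher of the two numbers; compound 1 sits at a lower value, a gap beyond the scatter. Compound 3, `O=C(O)COC/C=C1/C[C@H]2C[C@@H](O)[C@H](/C=N/NC(=O)Nc3ccc([N+](=O)[O-])cc3)[C@H]2C1`, is not yet measured. Compared with compound 2, (the two compounds have the same atoms and bonds and differ only in configuration as drawn: 1 of 6 stereo elements differ; a double bond is drawn E in compound 2 and Z in compound 3). Among the measured compounds shown here, no measured pair isolates this change, so its size is open. The expected step toward a lower number is roughly a 3.8-fold lower number from compound 2 to compound 3 (0.58 log units; beyond the scatter). For compound 3 the estimated value in this assay is 50 nM, within 12 nM to 200 nM.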

Compound 3, half-maximal inhibitory concentration: 20 nM
For compound 3 the middle estimate is 2.5-fold (0.40 log units) above the measured one; the measured number falls inside the stated range.
By their numbers in this assay, from the lowest: compounds 1 and 3 (each within the scatter of the next); then compound 2.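

In this assay, the geometry of the double bond in the oxa chain proves decisive, giving a 9.5-fold lower number from compound 2 to compound 3 (0.98 log units; beyond the scatter). This step can be assigned to the geometry alone because nothing else changes within the pair: the fact that compounds 2 and 3 differ only in the configuration as drawn. With the Z double bond in place, the swap of chain group shows no measurable effect, with carboxymethoxy and carboxymethyl giving no change at the digits printed from compound 1 to compound 3 (within the scatter).

Going by these compounds, whether the carboxymethyl chain of compound 1 would respond in the same way to an E double bond stays open. Also open, on these data alone, is how a longer chain, or an amide in place of the carboxylic acid, would behave with the Z double bond.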